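This account rests on a few compounds, and the source may have more. Where it says the series, first, only, none or still open, it means among the compounds named here.

Three compounds share one core and differ only in the chain on the oxygen of the aromatic ring. For the measured compounds named here, compound 1 `CC(C)CCOc1ccccc1C1CC(=O)c2ccccc2O1` and compound 2 `CCCOc1ccccc1C1CC(=O)c2ccccc2O1` are the first two; in a functional assay on J774.A1 cells (Mus musculus) for inhibition, read by immunoassay, with a stated time of 12 h, tested at 30 uM (a lower number here means less inhibition, a higher number more inhibition at the concentration tested (going by the name of the read-out)), compound 1 gives 43.6% and compound 2 gives 43.6%, and the step of no change at the digits printed from compound 1 to compound 2 (within the scatter). Compound 3 `CC(C)COc1ccccc1C1CC(=O)c2ccccc2O1` gives 33.5% in this assay, the lowest of the three numbers, because the step of a number 10.1 percentage points lower from compound 1 to compound 3 (beyond the scatter) and the step of a number 10.1 percentage points lower from compound 2 to compound 3 (beyond the scatter).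

Compound 4 `CCCCCOc1ccccc1C1CC(=O)c2ccccc2O1` is the next one. Its change from compound 3 is butyl in place of isopropyl on a saturated chain carbon bound to an oxygen on an aromatic ring. Going by the values given here, two measured steps bear on this. The step of a number 10.1 percentage points lower from compound 1 to compound 3 (beyond the scatter) and the step of a number 10.1 percentage points lower from compound 2 to compound 3 (beyond the scatter) were both modest drops, and each arrived at the isobutoxy chain of compound 3 from a chain without that shape. The change to compound 4 removes the isobutoxy chain and puts in a pentyloxy chain, while compound 1 and compound 2 showed that two such unbranched chains of different length sat at the same level. The expected step of a number 9.5 percentage points higher from compound 3 to compound 4 (within the scatter) is therefore a modest rise back toward that level in this assay. Compound 4 is estimated at 43%, with a range from 32% to 54%.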

Compound 4, a percentage reported as inhibition, at one concentration (the size of the read-out at that concentration, not a potency): 40.1%
Estimate against measurement, compound 4: 2.9 percentage points above; the measured number falls inside the stated range.
By their numbers in this assay, from the lowest: compounds 3, 4, 1 and 2 (each within the scatter of the next, the first and the last beyond it).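

In this assay, for the compounds shown here, the pentyloxy chain of compound 4 stands level with the chains of the two higher compounds, with a number 3.5 percentage points lower from compound 2 to compound 4 (within the scatter) and a number 3.5 percentage points lower from compound 1 to compound 4 (within the scatter), so moving to this chain from the propoxy chain or from the branched chain of compound 1 gives no step that can be told from the scatter. The new point concerns compound 3, which stood clearly apart from compound 1 and compound 2 but does not stand clearly apart from this new chain, with a number 6.6 percentage points higher from compound 3 to compound 4 (within the scatter), so butyl in place of isopropyl at this place leaves the two numbers inseparable and the isobutoxy chain no longer sits apart from every other chain shown. Nothing measured here explains why these chains read as they do.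

The compounds shown leave open whether a longer chain, such as decyloxy, or a chain ending in an amine or a carboxylic acid, would move the number beyond the scatter at this place. Each number comes from a single concentration, so the order of potency among these four compounds also stays open.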